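The source may report more compounds than this note shows. Statements on the series, on what has been measured and on what is new or still open speak of the compounds shown alone.

Measured compounds and their values:
compound 1, `CCCNS(=O)(=O)c1ccc(Nc2ncc3c(n2)N(c2ccn(C)n2)C(CC)C(=O)N3C)cc1` — 15000 nM
compound 2, `CCCCNS(=O)(=O)c1ccc(Nc2ncc3c(n2)N(C2CCCC2)[C@H](CC)C(=O)N3C)cc1` — 477 nM
compound 3, `CCCNS(=O)(=O)c1ccc(Nc2ncc3c(n2)N(C2CCCC2)[C@H](CC)C(=O)N3C)cc1` — 563 nM

In a functional assay on A549 cells (Homo sapiens) for antiproliferative activity, read by CCK-8 assay, with a stated time of 72 h (a higher number here means a weaker inhibitor of growth, a lower number a stronger inhibitor of growth), compound 1 gives 15000 nM, the highest number of the three; compound 3 gives 563 nM and compound 2 gives 477 nM. The difference between the core of compound 1 and the core of compound 3 is not broken down here; the two values simply show compound 1 far weaker.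

Between compound 3 and compound 2 the change is methyl in place of hydrogen on a saturated chain carbon, three bonds along the chain from a sulfonamide nitrogen, and the step it made was a 1.2-fold lower number from compound 3 to compound 2 (0.07 log units; within the scatter), within the scatter.

Compound 4, `CCCCNS(=O)(=O)c1ccc(Nc2ncc3c(n2)N(c2ccn(C)n2)C(CC)C(=O)N3C)cc1`, is not yet measured in this assay. It arises from compound 1 by methyl in place of hydrogen on a saturated chain carbon, three bonds along the chain from a sulfonamide nitrogen, the same change as between compound 3 and compound 2, made on the other core. Since that change moved compound 3 to compound 2 only by a 1.2-fold lower number from compound 3 to compound 2 (0.07 log units; within the scatter), a step of similar size is expected from compound 1 to compound 4, about a 1.2-fold lower number from compound 1 to compound 4 (0.08 log units; within the scatter), resting on that single precedent. Compound 4 is therefore estimated at 12500 nM, expected between 6000 nM and 26000 nM.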

Compound 4, concentration for 50% growth inhibition: 10600 nM
For compound 4 the middle estimate is 1.2-fold (0.07 log units) above the measured one, within the range that was stated.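

In this assay the propyl to butyl change, on a saturated chain carbon three bonds along the chain from a sulfonamide nitrogen, gives a 1.4-fold lower number from compound 1 to compound 4 (0.15 log units; within the scatter). The two cores give the same answer for this change: the same change on two cores in this assay, a 1.2-fold lower number (0.07 log units; within the scatter) from compound 3 to compound 2 and a 1.4-fold lower number (0.15 log units; within the scatter) from compound 1 to compound 4, 1.2-fold (0.08 log units) apart, within the scatter of two such steps

So in this series the change carries from one core to the other as a step too small to read, but this rests on only two pairs and does not show that the butyl chain improves growth inhibition on either core, nor that the agreement would hold on a third core.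

The compounds shown leave open whether a longer chain, or a chain ending in an amine or a carboxylic acid, in place of the butyl chain would give a step beyond the scatter on either core. Also open, going by these compounds, is whether such a step would be the same size on both cores, which a change this small cannot test.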